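Carboxylic acid to ethyl ester across two cores

This account rests on a few compounds, and the source may have more. Where it says the series, first, only, none or still open, it means among the compounds named here.

Measured compounds:
Compound 1 `C=CC(=O)N1CCCC(n2nc(-c3ccc(Oc4ccccc4)cc3)cc2C(=O)O)C1`: > 60000 nM, a limit of the assay, not a number.
Compound 2 `O=C(CCl)Nc1ccc(Cn2nc(-c3ccc(Oc4ccccc4)cc3)cc2C(=O)O)cc1`: 1500 nM
Compound 3 `C=CC(=O)N1CCCC(n2nc(-c3ccc(Oc4ccccc4)cc3)cc2C(=O)OCC)C1`: 44000 nM

All values come from a functional assay on Z-138 cells (Homo sapiens) for inhibition, read by luminescence and CellTiter-Glo, with a stated time of 72 h; on this read-out higher numbers stand for weaker inhibition and lower numbers for stronger inhibition. For compound 1 the assay gives only a limit, (the limit of > 60000 nM in this assay, at which 1 of the 3 values shown sits). Compound 2 and compound 1 carry different cores; the difference between the two cores is not broken down here. Within the core of compound 1, the change ethyl in place of hydrogen on an oxygen next to a carbonyl group gives an at least 1.3-fold lower number from compound 1 to compound 3 (0.13 log units; that floor lies within the scatter); since one end of that step is a limit, only its floor is known, and that floor lies within the usual scatter. Compound 2 stands lowest of the two numbers available, and its gap to compound 3 lies beyond the scatter.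

Compound 4 `CCOC(=O)c1cc(-c2ccc(Oc3ccccc3)cc2)nn1Cc1ccc(NC(=O)CCl)cc1` has not yet been measured in this assay. It relates to compound 2 as compound 3 relates to compound 1: the change (ethyl in place of hydrogen on an oxygen next to a carbonyl group), at a place described in the same words in both pairs, so this is the same change made on the core of compound 2. Among the measured compounds shown here, from compound 2 to compound 4 the expected step is a 1.4-fold lower number from compound 2 to compound 4 (0.13 log units; within the scatter), placed beside an at least 1.3-fold lower number from compound 1 to compound 3 (0.13 log units; that floor lies within the scatter), which rests on the single earlier instance of the change on compound 1 and compound 3 being, at its floor, within scatter. Compound 4 is therefore estimated at 1100 nM, with a likely range from 300 nM to 4500 nM.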

Compound 4, half-maximal inhibitory concentration: 400 nM
Compound 4: middle estimate off by 2.8-fold (0.44 log units), on the high side; measured number inside the range.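

In this assay, on the core of compound 2, ethyl in place of hydrogen on an oxygen next to a carbonyl group gives a 3.8-fold lower number from compound 2 to compound 4 (0.57 log units; beyond the scatter), so on this core the ethoxycarbonyl compound stands clear of the carboxy compound. Set beside the earlier instance of the change, this shows neither that the step carries over between the two cores at a like size nor that it differs between them: the same change on two cores in this assay, an at least 1.3-fold lower number (0.13 log units; that floor lies within the scatter) from compound 1 to compound 3 and a 3.8-fold lower number (0.57 log units; beyond the scatter) from compound 2 to compound 4; the limit leaves it open whether they differ Compound 1 gives > 60000 nM, which is a limit of the assay and not a number, so the two instances do not fix a size for this change that could be carried to a further core in the series.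

The compounds shown leave open whether the lower number on the core of compound 2 is particular to ethyl, or whether a methyl ester, a longer chain such as a butyl ester, or a primary amide in place of ethoxycarbonyl would give a step of like size. Also open, as far as these compounds go, is whether a third core, for instance one with a free amine in place of the chloroacetamide, would show the same step between a carboxylic acid and its ethyl ester.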